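Semicarbazide Analogue with Chlorophenyl Replacing Trifluoromethylphenyl

This account rests on a few compounds, and the source may have more. Where it says the series, first, only, none or still open, it means among the compounds named here.

Of the compounds shown here, three built on a shared core have been measured in a functional assay on NCI-H460 cells (Homo sapiens) for inhibition, read by MTT assay, with a stated time of 72 h; on this read-out higher numbers stand for weaker inhibition and lower numbers for stronger inhibition. Compound 1 `COc1cc(NC(C)CCCNC(=O)Nc2cccc(F)c2)c2ncccc2c1` gives 24000 nM. Compound 3 `COc1cc(NC(C)CCCNC(=O)Nc2cccc(C(F)(F)F)c2)c2ncccc2c1` gives 21000 nM, and the step of a 1.1-fold lower number from compound 1 to compound 3 (0.06 log units; within the scatter) shows how little that aryl substituent swap moved the number. Compound 2 `COc1cc(NC(C)CCCNC(=O)NNC(=O)Nc2ccc(C(F)(F)F)cc2)c2ncccc2c1` gives 12000 nM, the lowest of the three numbers, though its gaps to compound 3 and to compound 1 both lie within the scatter, so no ranking among the three can be claimed.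

Compound 4 `COc1cc(NC(C)CCCNC(=O)NNC(=O)Nc2cccc(Cl)c2)c2ncccc2c1` is the next member. It differs from compound 2 by 3-chlorophenyl in place of 4-(trifluoromethyl)phenyl on an amide-type nitrogen. Going by the values given here, the only measured step that bears on it is the aryl substituent change from compound 1 to compound 3, which stayed within the scatter. On that basis the step from compound 2 to compound 4 is expected to be small, with no direction beyond the scatter, giving an estimated 1.3-fold higher number from compound 2 to compound 4 (0.10 log units; within the scatter). Compound 4 is therefore expected to give about 15000 nM in this assay, within a range from 6000 nM to 40000 nM.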

Compound 4, half-maximal inhibitory concentration: 32000 nM
The estimate for compound 4 lay 2.1-fold (0.33 log units) below the measured number; low and high end bracket the measured number.
By their numbers in this assay, from the lowest: compounds 2, 3, 1 and 4 (each within the scatter of the next, the first and the last beyond it).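

In this assay, going by these compounds alone, the aryl group on the amide-type nitrogen of this semicarbazide series turns out to be able to move the number: 3-chlorophenyl in place of 4-(trifluoromethyl)phenyl gave a 2.7-fold higher number from compound 2 to compound 4 (0.43 log units; beyond the scatter) and is the first single-place change here to pass the scatter, whereas the earlier aryl swap had not. Exchanging the simpler aryl groups for ((3-chlorophenyl)carbamoyl)amino gave a 1.5-fold higher number from compound 3 to compound 4 (0.18 log units; within the scatter) and a 1.3-fold higher number from compound 1 to compound 4 (0.12 log units; within the scatter) and so shows no separable change on that exchange alone. No measurement at hand accounts for any of these steps.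

Going by these compounds, what a 3-(trifluoromethyl)phenyl or a 4-chlorophenyl group on this same nitrogen would give stays open, and with it which part of the change carries the step. So does the outcome for an amine or a carboxylic acid on that aryl ring.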